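A few compounds are considered here, and "the series" means these few. Any claim that something is new, unique, unknown or untested is made for them only; others in the source may bear on it.

Series in a functional assay on KB cells (Homo sapiens) for cytotoxicity (on this read-out higher numbers stand for weaker inhibition and lower numbers for stronger inhibition), so far:
compound 1 `C=CCOc1ccc2c(c1)C(=O)C=CC2=O` gives 10200 nM
compound 2 `O=C1C=CC(=O)c2cc(OCc3ccccc3)ccc21` gives 26200 nM
compound 3 `O=C1C=CC(=O)c2cc(Oc3ccco3)ccc21` is not yet measured

Compound 1 holds the lower of the two numbers, and so the stronger inhibition so far. The change under review is furan-2-yl in place of allyl on an oxygen on an aromatic ring on the core of compound 1, that is, furan-2-yl in place of allyl on an oxygen on an aromatic ring. Within the data shown here, one measured step bears on it. The step of a 2.6-fold higher number from compound 1 to compound 2 (0.41 log units; beyond the scatter) is modest, and there phenyl took the place of vinyl further out on the same oxygen substituent. Among the measured compounds shown here, no measured compound carries furan-2-yl, so this guide is thin. A modest move to a higher number is expected in this assay, and the estimated step is a 1.8-fold higher number from compound 1 to compound 3 (0.25 log units; within the scatter) in size. For compound 3 the estimated value is 18000 nM with an expected range from 7000 nM to 45000 nM overall.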

Compound 3, half-maximal inhibitory concentration: 15800 nM
Compound 3: the middle estimate sits 1.1-fold (0.06 log units) above what was measured; the range from low to high includes it.
By their numbers in this assay, from the lowest: compounds 1, 3 and 2 (each within the scatter of the next, the first and the last beyond it).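

In this assay, furan-2-yl on the oxygen on an aromatic ring gives a 1.5-fold higher number from compound 1 to compound 3 (0.19 log units; within the scatter) and so cannot be told apart from allyl. The earlier change gave a 2.6-fold higher number from compound 1 to compound 2 (0.41 log units; beyond the scatter) and lay beyond the scatter, so a ring-bearing substituent on this oxygen does not always leave the number where allyl puts it: compound 3 stays within the scatter, while compound 2 goes against any rule that such groups are tolerated without change. No evidence at hand accounts for either step.

The compounds shown leave open whether an amine, a carboxylic acid or a longer chain on this oxygen would shift the number in either direction. They also leave open whether any group here can bring the number clearly below that of compound 1, which gives 10200 nM in this assay.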